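The source may report more compounds than this note shows. Statements on the series, on what has been measured and on what is new or still open speak of the compounds shown alone.

Notes on the series. The shared core carries a different group at one aromatic carbon in each member. Compound 1 `COc1cccc(CNCCCNc2ccnc3cc(CCC(C)C)ccc23)c1O` gives 5390 nM in an ADME assay on HepG2 cells (Homo sapiens) for cytotoxicity, read by luminescence, CellTiter-Glo and ATP content, with a stated time of 72 h; on this read-out lower numbers stand for an effect already at smaller amounts and higher numbers for an effect only at larger amounts of compound; compound 2 `COc1cccc(CNCCCNc2ccnc3cc(-c4ccccc4)ccc23)c1O` gives 3210 nM; compound 3 `COc1cccc(CNCCCNc2ccnc3cc(Cc4ccc(F)cc4)ccc23)c1O` gives 4780 nM. Compound 3 lies within the scatter of both, nearest to compound 1 and furthest from compound 2. Compound 4 `COc1cccc(CNCCCNc2ccnc3cc(-c4ccc(F)cc4)ccc23)c1O` differs from compound 3 by 4-fluorophenyl in place of 4-fluorobenzyl on an aromatic carbon. The step of a 1.5-fold higher number from compound 2 to compound 3 (0.17 log units; within the scatter) is this same change run backwards, and a 1.7-fold lower number from compound 1 to compound 2 (0.23 log units; within the scatter) also stayed within the scatter, so no step beyond the scatter is expected in this assay, at most a slight move back toward the number of compound 2. Compound 4 is therefore estimated at 3600 nM, range 1800 nM to 7200 nM, which means an expected step of a 1.3-fold lower number from compound 3 to compound 4 (0.12 log units; within the scatter).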

Compound 4, half-maximal effective concentration: 6840 nM
Beside the measured number, compound 4's estimate is 1.9-fold (0.28 log units) below it; the measured number falls inside the stated range.
By their numbers in this assay, from the lowest: compounds 2, 3, 1 and 4 (each within the scatter of the next, the first and the last beyond it).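

For the compounds shown here, at this aromatic carbon, fluoro in place of hydrogen on the phenyl group gives the only step beyond the scatter that involves compound 4, a modest one: a 2.1-fold higher number from compound 2 to compound 4 (0.33 log units; beyond the scatter) in this assay. By contrast, 4-fluorophenyl in place of 4-fluorobenzyl gives a 1.4-fold higher number from compound 3 to compound 4 (0.16 log units; within the scatter) and 4-fluorophenyl in place of isopentyl gives a 1.3-fold higher number from compound 1 to compound 4 (0.10 log units; within the scatter), so neither change separates the compounds. Nothing available explains the step that fluoro brings. Open, going by these compounds, is how a chloro or methoxy group in place of that fluoro, or an amine at this aromatic carbon, would read in this assay, and whether any such group would go further than fluoro.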